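Halogen swap on the pyrimidine of an insulinotropic receptor agonist

The source may report more compounds than this note shows. Statements on the series, on what has been measured and on what is new or still open speak of the compounds shown alone.

Compound 1 `CCc1cnc(N2CCC(c3coc4c(N5CCc6cc(S(C)(=O)=O)ccc65)ncnc34)CC2)nc1`: 154%
Compound 2 `CS(=O)(=O)c1ccc2c(c1)CCN2c1ncnc2c(C3CCN(c4ncccn4)CC3)coc12`: 196%
Compound 3 `CS(=O)(=O)c1ccc2c(c1)CCN2c1ncnc2c(C3CCN(c4ncc(Cl)cn4)CC3)coc12`: 117%

In a functional assay on cells for agonist activity at Glucose-dependent insulinotropic receptor (Homo sapiens), read by a luciferase reporter, with a stated time of 4 h (a lower number here means a smaller maximal response, a higher number a larger maximal response), compound 3 gives the lowest maximal response of the three. Compound 4 `CS(=O)(=O)c1ccc2c(c1)CCN2c1ncnc2c(C3CCN(c4ncc(F)cn4)CC3)coc12` differs from compound 3 by fluoro in place of chloro on an aromatic carbon. Two measured steps end at compound 3: a number 79 percentage points lower from compound 2 to compound 3 (beyond the scatter) and a number 37 percentage points lower from compound 1 to compound 3 (beyond the scatter), both large reductions; the third, a number 42 percentage points higher from compound 1 to compound 2 (beyond the scatter), is a large rise. Going by the values given here, no step with fluoro has been measured, so its effect is read by analogy: fluoro is a halogen like chloro but a single, smaller atom, and the response is expected to lie between those of compound 3 and compound 2. Compound 4 is therefore expected to show a number 33 percentage points higher from compound 3 to compound 4 (beyond the scatter), giving an estimated 150% with a range of 110% to 195%.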

Compound 4, largest response reached (Emax), in percent of the reference or control that the assay uses: 229%
Compound 4: the middle estimate sits 79 percentage points below what was measured; measured number outside the range, above it.
By their numbers in this assay, from the lowest: compound 3; then compound 1; then compound 2; then compound 4.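

In this assay, the two halogens on this pyrimidine carbon are far from interchangeable: the change from 5-chloropyrimidin-2-yl to 5-fluoropyrimidin-2-yl gives a number 112 percentage points higher from compound 3 to compound 4 (beyond the scatter) as a large rise. Fluoro is also the only group shown that surpasses hydrogen (a number 33 percentage points higher from compound 2 to compound 4 (beyond the scatter)) and it surpasses ethyl as well (a number 75 percentage points higher from compound 1 to compound 4 (beyond the scatter)), whereas chloro and ethyl both fall short of hydrogen. Nothing available explains why a single-atom swap here moves the maximal response so far. Going by these compounds, how bromo, methoxy or a nitrile on this carbon would compare remains open.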